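Replacing the amino group of compound 2

This account rests on a few compounds, and the source may have more. Where it says the series, first, only, none or still open, it means among the compounds named here.

compound 1 `Cc1cc(-c2nc3ccccc3s2)ccc1N` gives < 1 nM
compound 2 `Nc1ccc(-c2nc3ccccc3s2)cc1Cl` gives < 1 nM
compound 3 `Nc1ccc(-c2nc3ccccc3s2)cc1I` gives < 1 nM

In a functional assay on MDA-MB-468 cells (Homo sapiens) for antiproliferative activity (on this read-out higher numbers stand for weaker inhibition and lower numbers for stronger inhibition), compound 2 gives < 1 nM as a limit of the assay and not as a number. The measured series stands on the limit of < 1 nM in this assay, at which 3 of the 3 values shown sit, and so shows no order among its members. Compound 4 `CC(=O)N(C(C)=O)c1ccc(-c2nc3ccccc3s2)cc1Cl` carries diacetylamino in place of amino on an aromatic carbon.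

The measured steps are a step that the two limits leave unreadable from compound 1 to compound 2 and a step that the two limits leave unreadable from compound 1 to compound 3 and also a step that the two limits leave unreadable from compound 2 to compound 3 in the same assay. All three swap chloro, iodo or methyl while the amino group stays in place, and none gives a size for the change made here. Among the compounds with values here, no measured compound lacks the amino group, so the expectation in this assay is loose and the range is wide. The expected direction is towards higher numbers and weaker inhibition, since compound 2 gives < 1 nM as a limit. The estimate means an expected at least 5.0-fold higher number from compound 2 to compound 4 (0.69 log units; beyond the scatter) in this assay. For compound 4 the estimated value is 5 nM with an expected range from 0.5 nM to 300 nM in this assay.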

Compound 4, half-maximal inhibitory concentration: > 1000 nM
Compound 4 ended at the assay's limit (the forecaster's own chance of this, stated with the estimate: 40%); middle value at least 200-fold (2.30 log units) away from the limit.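

In this assay, within the data shown here, diacetylamino in place of amino on an aromatic carbon gives the first step that can be read: an at least 1000-fold higher number from compound 2 to compound 4 (3.00 log units; beyond the scatter). Among these compounds, the steps among compound 1, compound 2 and compound 3 cannot be read, and all three keep the amino group, so only this change shows that activity depends on what the nitrogen carries. Compound 4 stands at a limit of the assay and not at a number: the limit of > 1000 nM in this assay, at which 1 of the 4 values shown sits.

The compounds shown leave open whether a single acetyl group on the nitrogen, as in acetylamino, or a smaller methylamino group would bring the same loss. They also leave open whether diacetylamino has the same effect with methyl or iodo in place of chloro, as in compound 1 and compound 3.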